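The compounds below may be only part of what the source reports. "The series", "measured", "known", "first", "only" and "open" are said of these compounds alone.

Of the compounds shown here, three built on one shared core have been measured in a functional assay on A549 cells (Homo sapiens) for cytotoxicity, read by MTT assay; a lower number here means a stronger inhibitor, a higher number a weaker inhibitor. Compound 1 `CCOC(=O)C12C(=O)OCC=C1COC2c1ccccc1F` gave only a limit in this assay, > 1000000 nM, so its true number is not known. Compound 2 `CCOC(=O)C12C(=O)OCC=C1COC2c1ccc(OC)cc1` gave 9300 nM in this assay. Compound 3 `CCOC(=O)C12C(=O)OCC=C1COC2c1ccc([N+](=O)[O-])cc1` gave 36800 nM in this assay; between these two measured compounds lies a 4.0-fold higher number from compound 2 to compound 3 (0.60 log units; beyond the scatter), a modest step.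

Compound 4 `CCOC(=O)C12C(=O)OCC=C1COC2c1ccccn1` has not been measured yet. It differs from compound 1 by pyridin-2-yl in place of 2-fluorophenyl on a saturated ring carbon. For the measured compounds named here, no measured step covers a change of this kind: the only measured step, a 4.0-fold higher number from compound 2 to compound 3 (0.60 log units; beyond the scatter), swaps one group on an aromatic ring for another, whereas here the whole aromatic ring is exchanged. Since compound 1 stands only at the limit of > 1000000 nM in this assay, at which 1 of the 3 values shown sits, the size of the step from compound 1 to compound 4 cannot be read from the data, and the measured compounds span from the number of compound 2 up to that limit. Compound 4 is therefore expected to fall somewhere in that span, estimated at 100000 nM with a range from 10000 nM to 1000000 nM. This estimate would mean an expected change of an at least 10-fold lower number from compound 1 to compound 4 (1.00 log units; beyond the scatter).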

Compound 4, half-maximal inhibitory concentration: > 1000000 nM
Compound 4 was reported as a limit; the forecaster's own chance of this, stated with the estimate: 35%; middle value at least 10-fold (1.00 log units) from the limit.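

For the compounds shown here, compound 4, like compound 1, gave only a limit in this assay, so no step between these two compounds can be read: the limit of > 1000000 nM in this assay, at which 2 of the 4 values shown sit. The compounds shown leave open where the true numbers of compound 1 and compound 4 lie, and whether 2-fluorophenyl or pyridin-2-yl gives the lower number.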